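The source may hold more compounds than are shown below. What is called first, only, known or untested is meant among the compounds shown, and "the series" means these compounds.

Working notes on the series: two compounds have been measured so far in a functional assay on K562 cells (Homo sapiens), read by MTT assay, with a stated time of 72 h (on this read-out higher numbers stand for weaker inhibition and lower numbers for stronger inhibition), compound 1 (`CNc1ncnc2c1c(-c1cc3ccccc3o1)cn2[C@@H]1O[C@H](CO)[C@@H](O)[C@H]1O`) and compound 2 (`Cc1ncnc2c1c(-c1cccs1)cn2[C@@H]1O[C@H](CO)[C@@H](O)[C@H]1O`). Compound 1 gives > 20000 nM, which is a limit and not a number. Compound 2 gives > 20000 nM, also a limit. The whole series therefore stands at the limit of > 20000 nM in this assay, at which 2 of the 2 values shown sit, and compound 2 has no numeric position.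

Compound 3 (`Cc1ncnc2c1c(-c1cc3ccccc3o1)cn2[C@@H]1O[C@H](CO)[C@@H](O)[C@H]1O`) differs from compound 2 in one place: 1-benzofuran-2-yl in place of thiophen-2-yl on an aromatic carbon. Going by the values given here, no measured pair shows the size of this change on its own. Compound 1 also carries 1-benzofuran-2-yl and sits at the limit of > 20000 nM, so no step beyond the scatter is expected in this assay. The estimated step is a number no higher from compound 2 to compound 3 (the limit leaves the size open). For compound 3 the expected value is 20000 nM, with an estimated range of 8000 nM to 30000 nM.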

Compound 3, half-maximal inhibitory concentration: 19500 nM
Compound 3: middle estimate off by 1.0-fold (0.01 log units), on the high side; the measured number falls inside the stated range.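

In this assay, going by these compounds alone, compound 3 gives 19500 nM, the first number rather than a limit. On the aromatic carbon of the five-membered ring, 1-benzofuran-2-yl in place of thiophen-2-yl gives an at least 1.0-fold lower number from compound 2 to compound 3 (0.01 log units; that floor lies within the scatter), and methyl in place of methylamino on the other aromatic carbon gives an at least 1.0-fold lower number from compound 1 to compound 3 (0.01 log units; that floor lies within the scatter). Each step starts from a limit and its floor lies within the scatter, so neither change has a known size, and the series remains at the edge of what this read-out can resolve: the limit of > 20000 nM in this assay, at which 2 of the 3 values shown sit.

Open, from the compounds shown here alone, is how thiophen-2-yl behaves with methylamino in place of methyl, which would allow the two changes to be compared on a second background. Also open, going by these compounds, is whether a carboxylic acid or a primary amine on the 1-benzofuran-2-yl group would give a number clearly lower than that of compound 3.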